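Replacing phenyl with cyano on the shared core

The source may hold more compounds than are shown below. What is called first, only, known or untested is meant among the compounds shown, and "the series" means these compounds.

Measured so far in an ADME assay on U2OS cells (Homo sapiens) for cytotoxicity; a higher number here means that more compound is tolerated, a lower number that less compound is tolerated (structure, then value):
Compound 1 `CCCCCCCCOc1ccc(C(=O)N/N=C/c2ccc([N+](=O)[O-])o2)cc1` gives > 200000 nM (a limit, not a number)
Compound 2 `CCCCOc1ccc(C(=O)N/N=C/c2ccc([N+](=O)[O-])o2)cc1` gives 46600 nM
Compound 3 `O=C(N/N=C/c1ccc([N+](=O)[O-])o1)c1ccc(-c2ccccc2)cc1` gives 109000 nM

Compound 3 holds the higher of the two true numbers in this assay at 109000 nM and compound 2 holds the lower at 46600 nM on that scale. Compound 1 is known only as a limit (> 200000 nM).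

Still unmeasured is compound 4 `N#Cc1ccc(C(=O)N/N=C/c2ccc([N+](=O)[O-])o2)cc1` which differs from compound 3 thus: cyano in place of phenyl on an aromatic carbon and so carries cyano in place of phenyl on an aromatic carbon, para to a large group.

Going by the values given here, no measured step involves cyano, so the evidence is indirect. The closest step alters the same aromatic carbon: a 2.3-fold higher number from compound 2 to compound 3 (0.37 log units; beyond the scatter) as phenyl replaces butoxy. Shortening the chain gave an at least 4.2-fold lower number from compound 1 to compound 2 (0.63 log units; beyond the scatter) as well. The remaining step, an at least 1.8-fold lower number from compound 1 to compound 3 (0.26 log units; that floor lies within the scatter) does not separate those two compounds. Among these three compounds, smaller groups at this carbon go with lower numbers, and none goes against that, so cyano is expected to lower the number modestly. The estimated change is a 2.7-fold lower number from compound 3 to compound 4 (0.44 log units; beyond the scatter) in this assay as an expectation only. For compound 4 the expected value is 40000 nM (estimated range 12000 nM to 120000 nM).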

Compound 4, half-maximal cytotoxic concentration: 21400 nM
Compound 4: middle estimate off by 1.9-fold (0.27 log units), on the high side; measured number inside the range.
By their numbers in this assay, from the lowest: compound 4; then compound 2; then compound 3. At a limit, above all of these: compound 1.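

Putting cyano on this aromatic carbon, para to a large group, gave the lowest true number of the series in this assay, with a 5.1-fold lower number from compound 3 to compound 4 (0.71 log units; beyond the scatter) and a 2.2-fold lower number from compound 2 to compound 4 (0.34 log units; beyond the scatter), so a short group with no ring lowers the number further than either phenyl or butoxy does. Going by these compounds alone, the comparison with the octyloxy compound gives an at least 9.3-fold lower number from compound 1 to compound 4 (0.97 log units; beyond the scatter), but that step is only a floor, and the top of the order is a limit rather than a number: the limit of > 200000 nM in this assay, at which 1 of the 4 values shown sits. Across all four groups at this carbon, the number now falls as the group gets smaller, and none of the compounds goes against that order, which earlier rested on only three groups.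

Four groups cannot show whether size alone tracks the number, since cyano also differs from phenyl in bringing a triple bond and a hydrogen-bond acceptor, and a compact group of another kind, such as an amine, a carboxylic acid or a chlorine atom, would help to separate these. A hexyloxy chain would also show how the number moves between butoxy and octyloxy, where the upper end is still only a limit.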